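A dimethylamino swap on the shared core

The source may hold more compounds than are shown below. What is called first, only, known or untested is meant among the compounds shown, and "the series" means these compounds.

Values in a functional assay on KB-VIN10 cells (Homo sapiens) for inhibition, with a stated time of 72 h; on this read-out lower numbers stand for stronger inhibition and higher numbers for weaker inhibition:
- Compound 1 `COc1ccc(S(=O)(=O)N2CCc3cccc(-c4ccc([N+](=O)[O-])cc4)c32)cc1` gives 51.3 nM
- Compound 2 `COc1ccc(S(=O)(=O)N2CCc3cccc(-c4ccc(F)c(F)c4)c32)cc1` gives 46 nM

For the measured compounds named here, compound 2 lies within the scatter of compound 1, the only other measured compound, so neither stands apart. Compound 3 `COc1ccc(S(=O)(=O)N2CCc3cccc(-c4ccc(N(C)C)cc4)c32)cc1` is next, and its difference from compound 2 is this: 4-(dimethylamino)phenyl in place of 3,4-difluorophenyl on an aromatic carbon. Going by the values given here, the only measured swap at this place is the step of a 1.1-fold lower number from compound 1 to compound 2 (0.05 log units; within the scatter) and it offers no sign of a larger move, so no step beyond the scatter is expected in this assay for this change. The expected move is a 1.2-fold lower number from compound 2 to compound 3 (0.06 log units; within the scatter) on this estimate. The estimated value for compound 3 is 40 nM with 13 nM to 125 nM as its expected range.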

Compound 3, half-maximal inhibitory concentration: 553 nM
For compound 3 the middle estimate is 14-fold (1.14 log units) below the measured one, outside the stated range (above it).
By their numbers in this assay, from the lowest: compounds 2 and 1 (each within the scatter of the next); then compound 3.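

In this assay, this position turns out to be sensitive to the choice of aryl group: 4-(dimethylamino)phenyl in place of 3,4-difluorophenyl gives a 12-fold higher number from compound 2 to compound 3 (1.08 log units; beyond the scatter), and dimethylamino in place of nitro gives an 11-fold higher number from compound 1 to compound 3 (1.03 log units; beyond the scatter). The earlier swap stayed within the scatter, whereas both new steps are large and run towards weaker inhibition. Nothing available explains this loss. Open, on these data alone, is whether 4-aminophenyl, with a primary amine, or a morpholine ring at this place would fall with dimethylamino or stay with the nitro and difluoro compounds.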